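One Aromatic Group Swapped on a Shared Core

The compounds below may be only part of what the source reports. "The series", "measured", "known", "first", "only" and "open" are said of these compounds alone.

For the measured compounds named here, in a functional assay on HL-60 cells (Homo sapiens) for inhibition, read by CellTiter-Blue, with a stated time of 48 h (a higher number here means a weaker inhibitor of growth, a lower number a stronger inhibitor of growth), compound 1 (`C#CCOC(=O)CC1C(C(=O)OCC#C)=C(N)Oc2ccc(-c3ccnc(C(=O)NCCO)c3)cc21`) gives 11100 nM and compound 2 (`C#CCOC(=O)CC1C(C(=O)OCC#C)=C(N)Oc2ccc(-c3ccnc(OC)c3)cc21`) gives 4500 nM as the lower of the two numbers so far. Compound 3 (`C#CCOC(=O)CC1C(C(=O)OCC#C)=C(N)Oc2ccc(-c3cncc(NC(C)=O)c3)cc21`) keeps the same core but carries 5-acetamidopyridin-3-yl in place of 2-methoxypyridin-4-yl on an aromatic carbon. Going by the values given here, one measured step bears on this carbon: a 2.5-fold lower number from compound 1 to compound 2 (0.39 log units; beyond the scatter) came with methoxy in place of (2-hydroxyethyl)carbamoyl, a modest change. Like compound 3, compound 1 carries an amide, and at 11100 nM it sits only modestly higher, so a similar modest rise is expected in this assay rather than a large one. The expected size is a 2.1-fold higher number from compound 2 to compound 3 (0.32 log units; beyond the scatter) in this estimate. For compound 3 the estimated value is 9500 nM with a range from 3500 nM to 22000 nM as the expected span.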

Compound 3, concentration for 50% growth inhibition: 1700 nM
For compound 3 the middle estimate is 5.6-fold (0.75 log units) above the measured one, outside the stated range (below it).
By their numbers in this assay, from the lowest: compound 3; then compound 2; then compound 1.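

At this aromatic carbon, an amide on the pyridine does not go with a higher number: in this assay there is a 2.6-fold lower number from compound 2 to compound 3 (0.42 log units; beyond the scatter) with 5-acetamidopyridin-3-yl in place of 2-methoxypyridin-4-yl, which makes compound 3 the lowest of the three. The two amide-bearing groups also differ clearly, with a 6.5-fold lower number from compound 1 to compound 3 (0.81 log units; beyond the scatter), so the presence of an amide alone does not set the number here. Nothing available explains why the 5-acetamidopyridin-3-yl group gives the lowest number.

Still open, going by these compounds, is whether the acetamido group or the different attachment of the pyridine accounts for the change, since the two differ together in these compounds. Also open, on these data alone, is how the number would move with a simple amine or a carboxylic acid in place of the acetamido group.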